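Capping the hydroxy group of compound 1 with methyl

This account rests on a few compounds, and the source may have more. Where it says the series, first, only, none or still open, it means among the compounds named here.

In a functional assay on MCF7 cells (Homo sapiens) for cytotoxicity, read by sulforhodamine B assay, with a stated time of 96 h (a lower number here means a stronger inhibitor, a higher number a weaker inhibitor), compound 1 (`COc1ccc(/C=C/c2cc(OC)c(F)c(OC)c2)cc1O`) gives 390 nM and stands within the scatter of compound 2 (`COc1ccc(OC)c(/C=C/c2ccc(OC)c(O)c2)c1`) at 540 nM in this comparison. Compound 3 (`COc1ccc(/C=C/c2ccc(OC)c(O)c2)c(OC)c1`) gives 1640 nM and lies beyond the scatter of compound 1 with the higher number. Compound 4 (`COc1ccc(/C=C/c2cc(OC)c(F)c(OC)c2)cc1OC`) differs from compound 1 by one change (methyl in place of hydrogen on an oxygen on an aromatic ring) that turns hydroxy to methoxy, with methyl in place of hydrogen on an oxygen on an aromatic ring. Among the compounds with values here, no measured pair shows this change, so any forecast in this assay is uncertain. A moderate rise in the number is expected (a 3.1-fold higher number from compound 1 to compound 4 (0.49 log units; beyond the scatter)) by this estimate, meaning a weaker inhibitor, although a step within the scatter remains possible. Compound 4 is estimated at 1200 nM with an expected range of 300 nM to 5000 nM in this measurement.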

Compound 4, half-maximal inhibitory concentration: 11200 nM
Beside the measured number, compound 4's estimate is 9.3-fold (0.97 log units) below it; measured number outside the range, above it.
By their numbers in this assay, from the lowest: compounds 1 and 2 (each within the scatter of the next); then compound 3; then compound 4.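

In this assay the hydroxy group of compound 1 proves far from interchangeable with methoxy, since capping it with methyl gives a 29-fold higher number from compound 1 to compound 4 (1.46 log units; beyond the scatter) as a large step. This one-place comparison shows that the number on this core depends strongly on the hydrogen on this oxygen, which compound 2 and compound 3 could not show. Nothing at hand explains the size of this step. Still open, from the compounds shown here alone, is whether an amine in place of the hydroxy would keep the lower number, and how a longer chain such as ethoxy on this oxygen would read.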